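The source may hold more compounds than are shown below. What is called first, only, known or untested is meant among the compounds shown, and "the series" means these compounds.

Compound 1 `C=C(C)c1cccc(C(C)(C)NC(=O)Nc2ccc(Cl)c(C(N)=O)c2)c1` gives 0.417 h
Compound 2 `C=C(C)c1cccc(C(C)(C)NC(=O)Nc2ccc3cccnc3c2)c1` gives 0.0983 h
Compound 3 `C/C(=N\O)c1cccc(C(C)(C)NC(=O)Nc2ccc(Cl)c(C(F)(F)F)c2)c1` gives 1.47 h

These half-lives come from an in vitro ADME assay on microsomes from liver (Mus musculus) for metabolic stability; a lower number here means that the compound disappears faster, a higher number that the compound lasts longer. Compound 3 has the highest of the three numbers, and its gaps to compound 1 and compound 2 both lie beyond the usual scatter. Compound 4 `C/C(=N\O)c1cccc(C(C)(C)NC(=O)Nc2ccc(Cl)c([N+](=O)[O-])c2)c1` has not been measured yet. It carries nitro in place of trifluoromethyl on an aromatic carbon, and the rest of the structure stays the same. Among the compounds with values here, no measured pair changes only one place, so the data offer no direct guide to this swap. Only a slight fall in this assay, within the scatter, is expected. The estimated change is a 1.6-fold lower number from compound 3 to compound 4 (0.21 log units; within the scatter). For compound 4 the expected half-life is 0.9 h, with an estimated range of 0.3 h to 2.5 h.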

Compound 4, half-life: 0.183 h
For compound 4 the middle estimate is 4.9-fold (0.69 log units) above the measured one; the whole stated range lies above it.
By their numbers in this assay, from the lowest: compounds 2 and 4 (each within the scatter of the next); then compound 1; then compound 3.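

Within the data shown here, compounds 3 and 4 are the first pair here that differ in one place only, so this swap on the aromatic carbon ortho to a chloro group can be read directly: this assay shows an 8.0-fold lower number from compound 3 to compound 4 (0.90 log units; beyond the scatter) for nitro in place of trifluoromethyl. The step lies beyond the scatter, so the group at this position clearly matters for how long the compound lasts. Nothing available here explains the fall. Still open, as far as these compounds go, is how a nitrile or an amine at this position would compare, and whether the same swap gives a similar step elsewhere.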